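The source may hold more compounds than are shown below. What is called first, only, known or untested is meant among the compounds shown, and "the series" means these compounds.

Measured so far in a physicochemical assay for solubility, read by HPLC, using the shake flask method, in phosphate buffer, with a stated time of 2 h, at pH 6.5; on this read-out lower numbers stand for lower solubility and higher numbers for higher solubility:
- Compound 1 `NC(=O)c1ccc(-c2cnc(N)c(-c3ccc(C(F)(F)F)cc3)n2)cc1` gives < 5000 nM as a limit.
- Compound 2 `Nc1ncc(-c2ccc(C(=O)O)cc2)nc1-c1ccc(C(F)(F)F)cc1` gives 95000 nM as a number.
- Compound 3 `COC(=O)c1ccc(-c2cnc(N)c(-c3ccc(C(F)(F)F)cc3)n2)cc1` gives < 5000 nM as a limit.

Compound 3 therefore has no number, only the limit of < 5000 nM in this assay, at which 2 of the 3 values shown sit, and nothing more. Compound 4 `Nc1ncc(-c2ccc(C(=O)N3CCC(O)CC3)cc2)nc1-c1ccc(C(F)(F)F)cc1` differs from it as follows: 4-hydroxypiperidin-1-yl in place of methoxy on a carbonyl carbon. Methoxy for amino gives a step that the two limits leave unreadable from compound 1 to compound 3 and so offers no size. The readable steps both concern hydroxy on the carbonyl carbon: an at least 19-fold higher number from compound 1 to compound 2 (1.27 log units; beyond the scatter) and an at least 19-fold lower number from compound 2 to compound 3 (1.27 log units; beyond the scatter) (both large). Compound 4 has no hydroxy there, so no such large rise is expected. The expected result is an at least 1.2-fold higher number from compound 3 to compound 4 (0.07 log units; that floor lies within the scatter) in this assay with a modest rise at best. For compound 4 the estimate is 6000 nM (expected range 2500 nM to 30000 nM).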

Compound 4, solubility: 19000 nM
Compound 4: middle estimate off by 3.2-fold (0.50 log units), on the low side; the range from low to high includes it.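

In this assay, 4-hydroxypiperidin-1-yl on the carbonyl carbon lifts the series clear of the limit, with an at least 3.8-fold higher number from compound 3 to compound 4 (0.57 log units; beyond the scatter) and an at least 3.8-fold higher number from compound 1 to compound 4 (0.57 log units; beyond the scatter). Hydroxy on that carbon stays ahead, with a 5.0-fold lower number from compound 2 to compound 4 (0.70 log units; beyond the scatter), so replacing it need not mean falling to the limit. Compound 1 and compound 3 hold limits, not numbers, so both rises are floors only: the limit of < 5000 nM in this assay, at which 2 of the 4 values shown sit.

Going by these compounds, how much of the rise belongs to the ring and how much to its hydroxy remains open. A plain piperidin-1-yl amide or a piperazine amide would separate the two.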